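This account rests on a few compounds, and the source may have more. Where it says the series, first, only, none or still open, it means among the compounds named here.

Of the compounds shown here, three with a shared core have been measured in a functional assay for antagonist activity at proteinase-activated receptor 1 (Homo sapiens); a lower number here means a stronger inhibitor, a higher number a weaker inhibitor. Compound 1 `c1ccc(-c2cc(N(CCCN3CCCCC3)Cc3cccc4ccccc34)on2)cc1` gives 500 nM. Compound 2 `COc1cccc(CN(CCCN2CCCC2)c2cc(-c3ccccc3)no2)c1` gives 3300 nM. Compound 3 `c1ccc(-c2cc(N(CCN3CCCCCC3)Cc3cccc4ccccc34)on2)cc1` gives 5000 nM, which is the highest of the three numbers; its gap to compound 2 lies within the scatter, while its gap to compound 1 is beyond it, as the step of a 10-fold higher number from compound 1 to compound 3 (1.00 log units; beyond the scatter) shows.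

Compound 4 `c1ccc(-c2cc(N(CCCN3CCCCCC3)Cc3cccc4ccccc34)on2)cc1` has not yet been measured. It differs from compound 3 by (azepan-1-yl)methyl in place of azepan-1-yl on a saturated chain carbon, two bonds along the chain from a nitrogen on an aromatic ring; seen one bond further out, this is 2-(azepan-1-yl)ethyl giving way to 3-(azepan-1-yl)propyl. Within the data shown here, only one measured step touches this change, a 10-fold higher number from compound 1 to compound 3 (1.00 log units; beyond the scatter), and that step altered both the ring and the chain length at once, so the two cannot be separated from the numbers at hand. Compound 4 restores the chain length of compound 1 while keeping the ring of compound 3, so it is expected to fall between them, and compound 4 is estimated at 1200 nM, within 300 nM to 4500 nM. The expected step is therefore a 4.2-fold lower number from compound 3 to compound 4 (0.62 log units; beyond the scatter), a lower number in this assay. The numbers at hand do not show what part of that step the ring alone would account for.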

Compound 4, half-maximal inhibitory concentration: 360 nM
Beside the measured number, compound 4's estimate is 3.3-fold (0.52 log units) above it; the measured number falls inside the stated range.
By their numbers in this assay, from the lowest: compounds 4 and 1 (each within the scatter of the next); then compounds 2 and 3 (each within the scatter of the next).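

In this assay, with azepan-1-yl held constant, going from 2-(azepan-1-yl)ethyl to 3-(azepan-1-yl)propyl gives a 14-fold lower number from compound 3 to compound 4 (1.14 log units; beyond the scatter) and so isolates chain length, which the earlier step of a 10-fold higher number from compound 1 to compound 3 (1.00 log units; beyond the scatter) could not do because it changed the ring as well. With the propyl chain held constant, azepan-1-yl in place of piperidin-1-yl gives a 1.4-fold lower number from compound 1 to compound 4 (0.14 log units; within the scatter), so on this chain the two rings cannot be told apart, and the gap between compound 1 and compound 3 goes with the chain length rather than with the ring. Nothing at hand explains why chain length matters so much at this position.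

The compounds shown leave open whether a still longer chain, such as 4-(azepan-1-yl)butyl, would hold, improve or lose this inhibition, since only the ethyl and propyl chains appear with azepan-1-yl. They also leave open whether the ring is equally interchangeable on the shorter chain, as 2-(piperidin-1-yl)ethyl would show, and whether an open-chain amine such as diethylamino can take the place of the ring on the propyl chain.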